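Replacing difluoromethyl with dimethylamino in compound 1

The source may report more compounds than this note shows. Statements on the series, on what has been measured and on what is new or still open speak of the compounds shown alone.

Going by the values given here, in a physicochemical assay for lipophilicity, using the shake flask method (a higher number here means a more lipophilic compound, a lower number a more polar compound), compound 1 (`C[C@H](Oc1ccc2ncc(/C=C/C(=O)O)c(C(F)F)c2c1)c1c(Cl)ccc(F)c1Cl`) gives 3.1, the higher of the two numbers so far. Compound 2 (`C[C@H](Oc1ccc(NC(=O)CC(=O)O)c(C2CC2)n1)c1c(Cl)ccc(F)c1Cl`) gives 1.4. The gap between these two numbers lies beyond the scatter. Among the compounds with values here, these two compounds differ in more than one place, so no measured single-place step is available as a guide. Compound 3 (`C[C@H](Oc1ccc2ncc(/C=C/C(=O)O)c(N(C)C)c2c1)c1c(Cl)ccc(F)c1Cl`) has dimethylamino in place of difluoromethyl on an aromatic carbon. The expected change is a decrease beyond the scatter, estimated as a number 0.70 log units lower from compound 1 to compound 3 (beyond the scatter). The estimate for compound 3 is 2.4, with an expected range of 1.7 to 3.1.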

Compound 3, distribution coefficient: 3.6
Estimate against measurement, compound 3: 1.20 log units below, outside the stated range (above it).
By their numbers in this assay, from the lowest: compound 2; then compound 1; then compound 3.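

In this assay, dimethylamino in place of difluoromethyl on an aromatic carbon gives a number 0.50 log units higher from compound 1 to compound 3 (beyond the scatter). Going by these compounds alone, this is the first single-place step, and it shows that this position, ortho to a 2-carboxyethenyl group, registers the exchange even though the same count of heavy atoms leaves and enters. No measurement at hand bears on the direction of this step.

From the compounds shown here alone, whether a methoxy group, a primary amine or a longer alkyl chain here would read closer to compound 1 or to compound 3 stays open. Also open, going by these compounds, is whether the step carries over to a core other than that of compound 1.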